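Fluoro for hydrogen on the anilide side of vinyl sulfonamides

The source may report more compounds than this note shows. Statements on the series, on what has been measured and on what is new or still open speak of the compounds shown alone.

Measured compounds in a functional assay on K562 cells (Homo sapiens) for cytotoxicity, read by trypan blue exclusion, with a stated time of 96 h; on this read-out higher numbers stand for weaker inhibition and lower numbers for stronger inhibition:
- compound 1 `COc1ccc(/C=C/S(=O)(=O)Nc2ccc(OC)c(F)c2)cc1`; compound 1 gives 1000 nM.
- compound 2 `COc1ccc(/C=C/S(=O)(=O)Nc2ccc(OC)cc2)cc1`; compound 2 gives 5000 nM.
- compound 3 `COc1cc(OC)c(/C=C/S(=O)(=O)Nc2ccc(OC)c(NC(C(=O)O)c3ccccc3)c2)c(OC)c1`; compound 3 gives 300 nM.

Compound 3 stands lowest of the three, and its steps to compound 1 and to compound 2 are both beyond the scatter. How the core of compound 3 differs from that of compound 2 is not broken down here.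

One change recurs. From compound 2 to compound 1 the difference is fluoro in place of hydrogen on an aromatic carbon, and it made the step of a 5.0-fold lower number from compound 2 to compound 1 (0.70 log units; beyond the scatter). Compound 4 `COc1cc(OC)c(/C=C/S(=O)(=O)Nc2ccc(OC)c(NC(C(=O)O)c3ccc(F)cc3)c2)c(OC)c1`, not yet measured, carries the same kind of change against compound 3: fluoro in place of hydrogen on an aromatic carbon. The surroundings are not the same, though. In compound 1 the fluoro sits ortho to a methoxy group and meta to a large group; in compound 4 it sits para to a large group, with no methoxy group named around it. Among the measured compounds shown here, with only one measured example of the change, and that at a different place, the earlier step is a weak guide.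

Compound 4 is expected to land near compound 3, with a step of about a 1.5-fold lower number from compound 3 to compound 4 (0.18 log units; within the scatter) in this assay, which leans toward a lower number because of a 5.0-fold lower number from compound 2 to compound 1 (0.70 log units; beyond the scatter) but is kept small since the place differs. The estimate for compound 4 is 200 nM, within 80 nM to 500 nM.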

Compound 4, half-maximal inhibitory concentration: 20 nM
Compound 4: the middle estimate sits 10-fold (1.00 log units) above what was measured; measured number outside the range, below it.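

In this assay, fluoro in place of hydrogen again lowers the number, with a 15-fold lower number from compound 3 to compound 4 (1.18 log units; beyond the scatter), so the direction of the change is the same on the two cores shown. The size of the step does not carry over from one core to the other: the same change on two cores in this assay, a 5.0-fold lower number (0.70 log units; beyond the scatter) from compound 2 to compound 1 and a 15-fold lower number (1.18 log units; beyond the scatter) from compound 3 to compound 4, 3.0-fold (0.48 log units) apart, beyond the scatter of two such steps. These two steps show that a result for this change on one core gave the direction but not the size on the other; they do not separate the effect of the core from the effect of place, as the fluoro in compound 4 stands on the 4-fluorophenyl group, para to a large group, and the fluoro in compound 1 stands on a different ring, and two pairs establish no rule for the wider series.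

The compounds shown leave open whether chloro, methyl or methoxy in place of the fluoro on the 4-fluorophenyl group of compound 4 would give a similar step. They also leave open whether the step persists when the carboxylic acid of compound 4 is replaced by a methyl ester or a primary amide, and whether it persists with the carboxy(phenyl)methyl group absent altogether.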